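Swapping amino for methoxy: where might compound 3 land?

The source may report more compounds than this note shows. Statements on the series, on what has been measured and on what is new or still open speak of the compounds shown alone.

In a functional assay (aorta) for inhibition, with Rattus norvegicus as the target (on this read-out lower numbers stand for stronger inhibition and higher numbers for weaker inhibition), compound 1 `Cc1nsc(-c2ccc(N3CCN(c4cccc(C(F)(F)F)c4)CC3)nn2)n1`, which carries trifluoromethyl, gives 0.3 nM. Compound 2 `Cc1nsc(-c2ccc(N3CCN(c4cccc(N)c4)CC3)nn2)n1` reads > 100 nM, and this is a limit of the assay, not a number. Compound 3 `COc1cccc(N2CCN(c3ccc(-c4nc(C)ns4)nn3)CC2)c1` has methoxy in place of amino on an aromatic carbon, meta to a large group (methoxy in place of amino on an aromatic carbon). Going by the values given here, only one measured step bears on this change: an at least 330-fold higher number from compound 1 to compound 2 (2.52 log units; beyond the scatter), which put amino in place of trifluoromethyl. That large step shows that the group at this place can move the read-out strongly, and amino marks the weak end. Methoxy itself has not been measured, so how far the number falls is uncertain, and the expected direction is toward lower numbers in this assay. The expected change is an at least 20-fold lower number from compound 2 to compound 3 (1.30 log units; beyond the scatter), a large but rough estimate. Compound 3 is estimated at 5 nM, with an expected range from 0.5 nM to 50 nM.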

Compound 3, half-maximal inhibitory concentration: 7 nM
Compound 3: the middle estimate sits 1.4-fold (0.15 log units) below what was measured; the range from low to high includes it.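

Methoxy in place of amino gives an at least 14-fold lower number from compound 2 to compound 3 (1.15 log units; beyond the scatter) in this assay, so a group at this place can recover much of what amino loses, without trifluoromethyl being present. The value of compound 2 is a limit of the assay and not a number: the limit of > 100 nM in this assay, at which 1 of the 3 values shown sits.

The recovery is only partial, with a 23-fold higher number from compound 1 to compound 3 (1.37 log units; beyond the scatter), so the three groups separate into three levels, with trifluoromethyl giving the lowest number, methoxy the middle one and amino the highest.

The compounds shown cannot tell which part of the change from amino to methoxy matters, the lost hydrogen-bond donor or the added carbon and oxygen. As far as these compounds go, how a hydroxy group or a dimethylamino group would read at this place remains open, and either would help to separate those two parts.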